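Amide reversal on the thioether chain: expected clearance

A few compounds are considered here, and "the series" means these few. Any claim that something is new, unique, unknown or untested is made for them only; others in the source may bear on it.

Two compounds of the series have been run in an ADME assay on microsomes from liver (Mus musculus) for metabolic stability, read by LC-MS, using NADPH, with a stated time of 45 min, tested at 0.5 uM; on this read-out higher numbers stand for fast clearance and lower numbers for slow clearance. Compound 1 `O=C(CCCSc1nc2cc(Cl)ccc2o1)N1CCCC1` gives 125 mL/min/g in this assay. Compound 2 `O=C(CCCc1nc2cc(Cl)ccc2o1)N1CCCC1`, the second measured compound, gives 115 mL/min/g in this assay. Of the two numbers compound 1 carries the larger figure, yet compound 2 lies within the usual scatter of it, so the two values show no difference that can be relied on.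

Compound 3 `O=C1CCCN1CCCSc1nc2cc(Cl)ccc2o1` has not yet been measured. It differs from compound 1 in one place: 2-oxopyrrolidin-1-yl in place of (pyrrolidin-1-yl)carbonyl on a saturated chain carbon, three bonds along the chain from a sulfur. Going by the values given here, no step between measured compounds covers a change of this kind, so the expectation rests on the pair already seen, which shows the read-out barely moving between the two chain variants. For compound 3 the step of a 1.1-fold lower number from compound 1 to compound 3 (0.06 log units; within the scatter) is expected to be small and without a direction beyond the scatter. Compound 3 is therefore estimated to give 110 mL/min/g in this assay, with a range from 55 mL/min/g to 220 mL/min/g.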

Compound 3, intrinsic clearance in a liver preparation (reported as CLH), per the amount of preparation that the assay uses: 51 mL/min/g
For compound 3 the middle estimate is 2.2-fold (0.33 log units) above the measured one, outside the stated range (below it).
By their numbers in this assay, from the lowest: compound 3; then compounds 2 and 1 (each within the scatter of the next).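

In this assay, putting 2-oxopyrrolidin-1-yl in place of (pyrrolidin-1-yl)carbonyl on a saturated chain carbon, three bonds along the chain from a sulfur, gives a 2.5-fold lower number from compound 1 to compound 3 (0.39 log units; beyond the scatter), the first separation in the series beyond the scatter; the change between compound 1 and compound 2 showed none. The leaving and entering groups match in the counts of rings, double bonds outside aromatic rings, hydrogen-bond donors and acceptors and in net charge, and differ only in heavy atoms, 7 leaving and 6 entering, so the read-out at this position responds to a swap that leaves most of these counts unchanged. Nothing at hand bears on why the number falls with this exchange.

As far as these compounds go, whether the same exchange lowers the number on the chain of compound 2, which carries no sulfur, stays open. Also open, from the compounds shown here alone, is how the read-out would respond to 2-oxopiperidin-1-yl at this position, or to a longer chain between the sulfur and the 2-oxopyrrolidin-1-yl group.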